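A Bromophenyl Variant of a Weakly Antiproliferative Benzothiazole Series

The source may hold more compounds than are shown below. What is called first, only, known or untested is meant among the compounds shown, and "the series" means these compounds.

Within the data shown here, compound 2 `COc1ccc2nc(N(Cc3cc(-c4cc(OC)c(OC)c(OC)c4)no3)c3nc4ccc(F)cc4s3)sc2c1` is one of two compounds measured in a functional assay on COLO 205 cells (Homo sapiens) for antiproliferative activity, read by MTT assay (a lower number here means a stronger inhibitor, a higher number a weaker inhibitor), where compound 2 gives 11800 nM. Its neighbour compound 1 `COc1ccc(-c2cc(CN(c3nc4ccc(F)cc4s3)c3nc4ccc(OC)cc4s3)on2)cc1` gives 11400 nM in this assay, and the two numbers lie within the scatter of each other, so the change from compound 1 to compound 2, a 1.0-fold higher number from compound 1 to compound 2 (0.01 log units; within the scatter), shows no effect on potency. Compound 3 `COc1ccc2nc(N(Cc3cc(-c4ccc(Br)cc4)no3)c3nc4ccc(F)cc4s3)sc2c1` has not yet been measured; it differs from compound 2 by 4-bromophenyl in place of 3,4,5-trimethoxyphenyl on an aromatic carbon. Among the measured compounds shown here, the only measured step bears on this position: the exchange of 4-methoxyphenyl for 3,4,5-trimethoxyphenyl left the number where it was. For the measured compounds named here, the move to 4-bromophenyl is a different exchange at the same place, and the data hold no step that resembles it, so no direction can be read from them. The most reasonable expectation is therefore that compound 3 stays near compound 2, with a step of a 1.2-fold lower number from compound 2 to compound 3 (0.07 log units; within the scatter) that is not expected to leave the scatter. Compound 3 is accordingly estimated at 10000 nM in this assay, within a range from 4000 nM to 25000 nM.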

Compound 3, half-maximal inhibitory concentration: 7000 nM
For compound 3 the middle estimate is 1.4-fold (0.15 log units) above the measured one, and the stated range covers the measured number.
By their numbers in this assay, from the lowest: compounds 3, 1 and 2 (each within the scatter of the next).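

Among these compounds, with the third aryl group at this position, on the aromatic carbon next to the ring nitrogen, the series moves for the first time away from methoxy-bearing rings: replacing 3,4,5-trimethoxyphenyl with 4-bromophenyl gives a 1.7-fold lower number from compound 2 to compound 3 (0.23 log units; within the scatter) in this assay and so does not separate the two compounds. The comparison with the 4-methoxyphenyl group, where bromo takes the place of methoxy, gives a 1.6-fold lower number from compound 1 to compound 3 (0.21 log units; within the scatter) and likewise stays inside the scatter, so that in these three compounds a phenyl ring at this place gives numbers that cannot be told apart, whether it carries bromo, one methoxy or three methoxy groups, and whether the group holds hydrogen-bond acceptors or none. No measurement is at hand that would account for this result.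

All three groups are substituted phenyl rings, so the compounds shown leave open whether a step beyond the scatter can be reached at this position at all. A phenyl ring bearing an amine or a carboxylic acid, or a saturated ring such as cyclohexyl in place of the phenyl ring, would test this.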